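The source may report more compounds than this note shows. Statements on the series, on what has been measured and on what is new or still open speak of the compounds shown alone.

Measured in a functional assay (aorta) with Rattus norvegicus as the target; a higher number here means that more compound is needed for the effect, a lower number that less compound is needed:
- compound 1 `CN(C)/C(=N\C#N)C1=CC(C)(C)Oc2ccc(C#N)cc21`: 5010 nM
- compound 2 `CN(C)/C(=N\C#N)C1=CC(C)(C)Oc2ccc(C(F)(F)F)cc21`: 12600 nM

Compound 2 holds the higher of the two numbers. The change to compound 3 `CN(C)/C(=N\C#N)C1=CC(C)(C)Oc2ccc(Br)cc21` is bromo in place of trifluoromethyl on an aromatic carbon. For the measured compounds named here, one measured step bears on it, also a change on that aromatic carbon: a 2.5-fold higher number from compound 1 to compound 2 (0.40 log units; beyond the scatter), modest and beyond the scatter. A step of similar modest size is therefore expected in this assay, tentatively towards a lower number, though one step gives little support for any direction. The expected step is a 1.8-fold lower number from compound 2 to compound 3 (0.26 log units; within the scatter). The estimate for compound 3 is 7000 nM, with an expected range of 2500 nM to 16000 nM.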

Compound 3, half-maximal effective concentration: > 31600 nM
Compound 3: only a limit was reported; the forecaster's own chance of this, stated with the estimate: 3%; middle value at least 4.5-fold (0.65 log units) from the limit.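

At this aromatic carbon, the substituent moves the number further than the step from compound 1 to compound 2 alone showed: in this assay, the bromo change gives an at least 2.5-fold higher number from compound 2 to compound 3 (0.39 log units; beyond the scatter), and against the cyano group it gives an at least 6.3-fold higher number from compound 1 to compound 3 (0.79 log units; beyond the scatter). Both steps lie beyond the scatter, so among these three compounds, compound 3 needs the most compound for the effect. Its reading is a limit and not a number: the limit of > 31600 nM in this assay, at which 1 of the 3 values shown sits.

Going by these compounds, how far compound 3 truly lies past that limit remains open. So does where a nitro group or an amide on the same aromatic carbon would fall relative to cyano, trifluoromethyl and bromo.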